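Two Carboxy Groups on the Amide Nitrogen of Compound 1

The compounds below may be only part of what the source reports. "The series", "measured", "known", "first", "only" and "open" are said of these compounds alone.

Compound 1 `CCN(CC)CCNC(=O)c1ccc(C(CC)(CC)c2ccc(OCS(=O)(=O)c3ccccc3)c(C)c2)n1CC` gives 6270 nM in a functional assay on BXPC-3 cells (Homo sapiens) for antiproliferative activity, read by MTT assay, with a stated time of 24 h; a higher number here means a weaker inhibitor, a lower number a stronger inhibitor.
Compound 2 `CCn1c(C(=O)N[C@@H](CO)C(C)C)ccc1C(CC)(CC)c1ccc(OCS(=O)(=O)c2ccccc2)c(C)c1` gives 13200 nM.
Compound 3 `CCn1c(C(=O)NCC(=O)O)ccc1C(CC)(CC)c1ccc(OCS(=O)(=O)c2ccccc2)c(C)c1` gives > 50000 nM, which is a limit of the assay, not a number.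

Compound 1 has the lowest of the two numbers measured; the nearest is a 2.1-fold higher number from compound 1 to compound 2 (0.32 log units; beyond the scatter). Compound 4 `CCn1c(C(=O)N[C@H](CCC(=O)O)C(=O)O)ccc1C(CC)(CC)c1ccc(OCS(=O)(=O)c2ccccc2)c(C)c1` changes compound 1 by 1,3-dicarboxypropyl in place of 2-(diethylamino)ethyl on an amide-type nitrogen. Within the data shown here, two measured steps bear on this change: an at least 7.9-fold higher number from compound 1 to compound 3 (0.90 log units; beyond the scatter) and an at least 3.7-fold higher number from compound 2 to compound 3 (0.57 log units; beyond the scatter), both toward a weaker inhibitor. For compound 3 these steps end at the limit of > 50000 nM in this assay, at which 1 of the 3 values shown sits. A chain carrying two carboxy groups is expected to move the number the same way, at least as far, so a limit is likely. Compound 4 is therefore estimated at 90000 nM, within 25000 nM to 400000 nM. The expected step is a 14-fold higher number from compound 1 to compound 4 (1.16 log units; beyond the scatter).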

Compound 4, half-maximal inhibitory concentration: > 50000 nM
Compound 4: no number, only a limit (the forecaster's own chance of this, stated with the estimate: 75%); the middle value is on the limit's open side.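

In this assay compound 4 gives > 50000 nM, which is a limit of the assay and not a number. Putting 1,3-dicarboxypropyl on the amide-type nitrogen gives an at least 7.9-fold higher number from compound 1 to compound 4 (0.90 log units; beyond the scatter) and an at least 3.7-fold higher number from compound 2 to compound 4 (0.57 log units; beyond the scatter), while the step from compound 3 to compound 4 cannot be read, as both ends are limits. Compound 3 and compound 4, the two compounds with carboxy groups on this chain, both stand at the same limit: the limit of > 50000 nM in this assay, at which 2 of the 4 values shown sit.

From the compounds shown here alone, it remains open how a methyl ester in place of the carboxylic acids would read in this assay. The same holds for a primary amine on a longer chain at this nitrogen.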